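The source may hold more compounds than are shown below. What is called first, only, known or untested is meant among the compounds shown, and "the series" means these compounds.

Three compounds of this series carry numbers in a functional assay on MKN-45 cells (Homo sapiens) for antiproliferative activity, tested at 1 uM; a lower number here means less inhibition, a higher number more inhibition at the concentration tested (going by the name of the read-out). Compound 1 `CCOC(=O)c1ccc(CO/N=C/c2c(C)nn(C)c2Oc2ccc(Cl)cc2)cc1` gives 20.9% in this assay. Compound 2 `COc1cccc(CO/N=C/c2c(C)nn(C)c2Oc2ccccc2)c1` gives -19.6% in this assay. Compound 3 `CC(C)c1nn(-c2ccccc2)c(Oc2ccc(Cl)cc2)c1/C=N/OCc1ccc(C(=O)OC(C)(C)C)cc1` gives -27% in this assay. Among these three numbers compound 2 stands second highest; its nearest neighbour is compound 3, whose number lies within the scatter of that of compound 2, and its furthest is compound 1, whose number lies beyond the scatter, above that of compound 2. Compound 4 `Cc1ccc(CO/N=C/c2c(C)nn(C)c2Oc2ccccc2)cc1` has not yet been measured in this assay. It differs from compound 2 in one place: 4-methylphenyl in place of 3-methoxyphenyl on a saturated chain carbon bound to an oxygen on an unsaturated carbon. For the measured compounds named here, no step between two measured compounds isolates this part of the structure, so no measured step size is available for it. With the rest of the molecule kept as in compound 2, the change is expected to move the number by no more than the scatter, in no firm direction. The step expected here is a number 7.6 percentage points higher from compound 2 to compound 4 (within the scatter). For compound 4 the estimate in this assay is -12%, with a range from -35% to 12%.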

Compound 4, a percentage reported as inhibition, at one concentration (the size of the read-out at that concentration, not a potency): 17.9%
For compound 4 the middle estimate is 29.9 percentage points below the measured one; measured number above the stated range.
By their numbers in this assay, from the lowest: compounds 3 and 2 (each within the scatter of the next); then compounds 4 and 1 (each within the scatter of the next).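

In this assay the aryl group on the saturated chain carbon bound to an oxygen on an unsaturated carbon proves to be a sensitive place: 4-methylphenyl in place of 3-methoxyphenyl gives a number 37.5 percentage points higher from compound 2 to compound 4 (beyond the scatter), a large step and the only one shown that isolates a single part of the structure. Exchanging one substituted six-membered aromatic ring for another is therefore enough to carry the number from negative to positive with the rest of the molecule unchanged. No measurement shown bears on the reason for this step. 

The exchange alters both the substituent and its ring position, so 3-methylphenyl and 4-methoxyphenyl would be needed to separate the two. As far as these compounds go, whether unsubstituted benzyl, 4-chlorophenyl or a 4-carboxylic acid on this ring would keep the higher number remains open.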